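Swapping the Aryl Ring on a Shared Core

The compounds below may be only part of what the source reports. "The series", "measured", "known", "first", "only" and "open" are said of these compounds alone.

Of the compounds shown here, two built on one shared core have been measured in a functional assay on KM12 cells (Homo sapiens) for inhibition, read by sulforhodamine B assay, with a stated time of 48 h, tested at 10 uM; a lower number here means less inhibition, a higher number more inhibition at the concentration tested (going by the name of the read-out). Compound 1 `O=Cc1ccc(-c2cn3ccnc3c(-c3ccc4ncn(C5CCCCC5)c4c3)n2)cc1` carries a formyl group on its outer aromatic ring and gives 3.69%. Compound 2 `Brc1ccc(-c2cn3ccnc3c(-c3ccc4ncn(C5CCCCC5)c4c3)n2)cc1` carries bromo in place of formyl and gives 23.3%. The step of a number 19.6 percentage points higher from compound 1 to compound 2 (beyond the scatter) lies beyond the scatter, so compound 2 stands highest of the two numbers, with compound 1 as the nearest and lower neighbour.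

Compound 3 `COc1ccccc1-c1cn2ccnc2c(-c2ccc3ncn(C4CCCCC4)c3c2)n1` has not been measured. Its change from compound 2 is 2-methoxyphenyl in place of 4-bromophenyl on an aromatic carbon. Going by the values given here, no measured step covers this exchange; the only known step concerns formyl against bromo on the same ring, and it shows merely that a change there can move the read-out by a modest amount in either direction. The new group is therefore expected to give a number near or somewhat under that of compound 2. Compound 3 is expected to give 14%, between 0% and 38%, which would mean an expected step of a number 9.3 percentage points lower from compound 2 to compound 3 (within the scatter).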

Compound 3, a percentage reported as inhibition, at one concentration (the size of the read-out at that concentration, not a potency): 3.58%
Beside the measured number, compound 3's estimate is 10.4 percentage points above it; the range from low to high includes it.
By their numbers in this assay, from the lowest: compounds 3 and 1 (each within the scatter of the next); then compound 2.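

In this assay the exchange of 4-bromophenyl for 2-methoxyphenyl gives a number 19.7 percentage points lower from compound 2 to compound 3 (beyond the scatter), so the read-out at this position has now responded to a second change, not only to formyl against bromo. Two different outer rings also come out alike, with a number 0.1 percentage points lower from compound 1 to compound 3 (within the scatter), which leaves compound 2 alone above both other compounds. The exchange alters both the group and its place on the ring in one move, and nothing available separates those two changes or explains the drop.

As far as these compounds go, it remains open whether an amine or a carboxylic acid on this outer ring would match or pass compound 2. A single concentration also leaves open how compound 2 would behave across a range of concentrations.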